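Swapping the hydroxyphenyl arm for a difluorophenyl arm

The source may report more compounds than this note shows. Statements on the series, on what has been measured and on what is new or still open speak of the compounds shown alone.

Compound 1, `CN(C)CCn1c(=O)c(=Cc2ccc(F)c(F)c2)s/c1=C1\C(=O)Nc2cc(F)ccc21`, gives 6400 nM in a functional assay on NCI-H460 cells (Homo sapiens) for inhibition, read by MTT assay, with a stated time of 72 h; a lower number here means a stronger inhibitor, a higher number a weaker inhibitor.
Compound 2, `CCN(CC)CCCn1c(=O)c(=Cc2ccccc2O)s/c1=C1\C(=O)Nc2ccc(Br)cc21`, gives 51700 nM in this assay.
Compound 3, `CCN(CC)CCCn1c(=O)c(=Cc2ccccc2O)s/c1=C1\C(=O)Nc2ccccc21`, reaches only the limit of > 200000 nM in this assay.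

Compound 3 thus stands at a limit rather than a number, above every measured value shown. Compound 4, `CCN(CC)CCCn1c(=O)c(=Cc2ccc(F)cc2F)s/c1=C1\C(=O)Nc2ccccc21`, differs from it in one place: 2,4-difluorophenyl in place of 2-hydroxyphenyl on a double-bonded chain carbon bound to an aromatic carbon. Within the data shown here, the single measured step, an at least 3.8-fold higher number from compound 2 to compound 3 (0.58 log units; beyond the scatter), concerns a different position and does not bear on this change. Compound 1 also carries a difluorophenyl arm and gives 6400 nM, but it differs from compound 4 in further places, so it is only a loose pointer. A downward step is therefore expected, an at least 5.0-fold lower number from compound 3 to compound 4 (0.69 log units; beyond the scatter), with wide uncertainty. Compound 4 is estimated at 40000 nM, between 8000 nM and 200000 nM.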

Compound 4, half-maximal inhibitory concentration: 5470 nM
Compound 4: the middle estimate sits 7.3-fold (0.86 log units) above what was measured, and the stated range ends above it.
By their numbers in this assay, from the lowest: compounds 4 and 1 (each within the scatter of the next); then compound 2. At a limit, above all of these: compound 3.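

Among these compounds, on the double-bonded chain carbon bound to an aromatic carbon, 2,4-difluorophenyl in place of 2-hydroxyphenyl gives an at least 36-fold lower number from compound 3 to compound 4 (1.56 log units; beyond the scatter) in this assay, a large step and the first measured change at this arm. Compound 3 stands at a limit of the assay, so the true size of the step stays unknown: the limit of > 200000 nM in this assay, at which 1 of the 4 values shown sits.

The compounds shown leave open whether the fluorines matter or only the loss of the hydroxyl, since a plain phenyl or a methoxyphenyl arm is not among them. Going by these compounds, it also remains open how the 2,4-difluorophenyl arm behaves alongside the bromo of compound 2.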